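Amide nitrogen variation: from phenyl to pyridin-2-yl

The source may hold more compounds than are shown below. What is called first, only, known or untested is meant among the compounds shown, and "the series" means these compounds.

The set shares the core of compound 1 `CC(C)[C@H](C(=O)NC(C)(C)C)c1ccc(Cl)cc1` and differs only in the group on the amide-type nitrogen. In a functional assay on CHO cells for agonist activity at Free fatty acid receptor 2 (Homo sapiens), read by cAMP accumulation (on this read-out lower numbers stand for smaller maximal responses and higher numbers for larger maximal responses), compound 1 gives < 30%, a limit of the assay rather than a number. Compound 2 `CC(C)[C@H](C(=O)NCc1ccccc1)c1ccc(Cl)cc1` carries benzyl there; in this assay compound 2 gives < 30%, again a limit. Compound 3 `CC(C)[C@H](C(=O)Nc1ccccc1)c1ccc(Cl)cc1` carries phenyl; in this assay compound 3 gives < 30%, also a limit. Because of the limit of < 30% in this assay, at which 3 of the 3 values shown sit, the steps a step that the two limits leave unreadable from compound 1 to compound 2, a step that the two limits leave unreadable from compound 1 to compound 3 and a step that the two limits leave unreadable from compound 2 to compound 3 are all unreadable. Compound 4 `CC(C)[C@H](C(=O)Nc1ccccn1)c1ccc(Cl)cc1` differs from compound 3 by pyridin-2-yl in place of phenyl on an amide-type nitrogen. No readable step exists for any change at this nitrogen, so no shift beyond the scatter is expected. The step is estimated as a step that the limit leaves unreadable from compound 3 to compound 4. Compound 4 is expected to give 20%, between 5% and 45%, most likely again only a limit.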

Compound 4, largest response reached (reported as efficacy), in percent of the reference or control that the assay uses: 92%
Compound 4: middle estimate off by 72 percentage points, on the low side; the whole stated range lies below it.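

In this assay, going by these compounds alone, pyridin-2-yl in place of phenyl gives a number at least 62 percentage points higher from compound 3 to compound 4 (beyond the scatter), the first readable step at this nitrogen, and it comes from a swap that keeps the ring size and the heavy-atom count. The same group gives a number at least 62 percentage points higher from compound 2 to compound 4 (beyond the scatter) and a number at least 62 percentage points higher from compound 1 to compound 4 (beyond the scatter), so the group on this nitrogen can decide the maximal response. The steps among the other three compounds remain unreadable: the limit of < 30% in this assay, at which 3 of the 4 values shown sit.

On these data alone, whether the rise is specific to pyridin-2-yl or extends to pyridin-3-yl, pyridin-4-yl or pyrimidin-2-yl remains open. The compounds shown also leave open whether a methyl group on the pyridin-2-yl ring keeps the response.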